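Removing One Methoxy Group from a Trimethoxyphenyl Ring

The source may report more compounds than this note shows. Statements on the series, on what has been measured and on what is new or still open speak of the compounds shown alone.

Of the compounds shown here, three sharing a related core have been measured in a functional assay on RXF 393 cells (Homo sapiens) for inhibition, read by sulforhodamine B assay, with a stated time of 48 h; a higher number here means that more compound is tolerated, a lower number that less compound is tolerated. Compound 1 `COc1cc(-c2cc(/C=C/C(=O)c3ccc(N)cc3)[nH]n2)cc(OC)c1OC` gives 7790 nM, compound 2 `COc1ccc(-c2cc(/C=C/C(=O)c3ccc(N)cc3)[nH]n2)cc1OC` gives 15900 nM, and compound 3 `COc1cc(C(=O)/C=C/c2cc(-c3cc(OC)c(OC)c(OC)c3)n[nH]2)cc(OC)c1OC` gives 5680 nM. Compound 1 and compound 2 differ in one place (hydrogen in place of methoxy on an aromatic carbon), and this change made a 2.0-fold higher number from compound 1 to compound 2 (0.31 log units; beyond the scatter). Compound 4 `COc1ccc(-c2cc(/C=C/C(=O)c3cc(OC)c(OC)c(OC)c3)[nH]n2)cc1OC` has not yet been measured; it carries the same change relative to compound 3 (hydrogen in place of methoxy on an aromatic carbon), at a place described in the same words as in the first pair. The difference between the core of compound 1 and the core of compound 3 is not broken down here, so the two pairs sit on cores whose relation is only partly known. Given that the earlier change gave a 2.0-fold higher number from compound 1 to compound 2 (0.31 log units; beyond the scatter), the step from compound 3 to compound 4 is expected to be a 1.8-fold higher number from compound 3 to compound 4 (0.25 log units; within the scatter) in this assay. Compound 4 is therefore estimated at 10000 nM, with a likely range from 5000 nM to 20000 nM.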

Compound 4, concentration lethal to 50% of the cells: 6510 nM
Beside the measured number, compound 4's estimate is 1.5-fold (0.19 log units) above it, within the range that was stated.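

In this assay, putting hydrogen in place of a methoxy group gave a 1.1-fold higher number from compound 3 to compound 4 (0.06 log units; within the scatter), a step too small to separate from the ordinary spread of repeat measurements, whereas the same swap on the core of compound 1 gave a 2.0-fold higher number from compound 1 to compound 2 (0.31 log units; beyond the scatter), which lies beyond that spread. Even so, the two steps cannot be told apart, so the data fit the change carrying over from one core to the other: the same change on two cores in this assay, a 2.0-fold higher number (0.31 log units; beyond the scatter) from compound 1 to compound 2 and a 1.1-fold higher number (0.06 log units; within the scatter) from compound 3 to compound 4, 1.8-fold (0.25 log units) apart, within the scatter of two such steps. Within the data shown here, this does not prove that the change acts identically on both cores, as only one pair per core is available and a small real difference could stay hidden in the scatter.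

At this place on the ring, the compounds shown hold only methoxy or hydrogen, so it remains open how a hydroxyl group, a chlorine atom or a longer chain such as ethoxy would read. Also open, going by these compounds, is whether the two cores would still respond alike with those groups in this assay.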